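A few compounds are considered here, and "the series" means these few. Any claim that something is new, unique, unknown or untested is made for them only; others in the source may bear on it.

Two compounds of the series have numbers in a functional assay on HCT-15 cells (Homo sapiens) for cytotoxicity, read by sulforhodamine B assay, with a stated time of 48 h; a lower number here means a stronger inhibitor of growth, a higher number a weaker inhibitor of growth. Compound 1 `ClCc1ccc(Cn2cnc3c(Cl)ncnc32)cc1` gives 1950 nM in this assay. Compound 2 `ClCc1cccc(Cn2cnc3ncnc(Cl)c32)c1` gives 1940 nM in this assay. Compound 2 stands level with compound 1 on these numbers; the two values lie within the usual scatter of each other, so neither compound can be set apart from the other in this assay.

Compound 3 `ClCc1cccc(Cn2cnc3nc(Cl)nc(Cl)c32)c1` has not yet been measured in this assay. It differs from compound 2 in one place: chloro in place of hydrogen on an aromatic carbon. Among the compounds with values here, no step of this kind between measured compounds exists, so there is no measured precedent for the effect of this change. The expectation for compound 3 is a step of a 1.2-fold lower number from compound 2 to compound 3 (0.08 log units; within the scatter) in this assay, that is, no change beyond the scatter. Compound 3 is accordingly estimated at 1600 nM in this assay, with a range from 500 nM to 5000 nM.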

Compound 3, concentration for 50% growth inhibition: 950 nM
Compound 3: middle estimate off by 1.7-fold (0.23 log units), on the high side; measured number inside the range.
By their numbers in this assay, from the lowest: compound 3; then compounds 2 and 1 (each within the scatter of the next).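

At the ring carbon between two ring nitrogen atoms, chloro in place of hydrogen gives a 2.0-fold lower number from compound 2 to compound 3 (0.31 log units; beyond the scatter) in this assay. Within the data shown here, this is the first measured step, and it shows that this position can carry a chloro group without loss of growth inhibition, with a modest move towards stronger inhibition. No measurement shown bears on the reason for this step.

As far as these compounds go, whether this step belongs to chloro alone remains open, since an amine, a methoxy group or fluoro at the same carbon would show whether other groups there give a similar, larger or opposite step. Also open, from the compounds shown here alone, is whether the same replacement on the core of compound 1 would give a step of similar size.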